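This account rests on a few compounds, and the source may have more. Where it says the series, first, only, none or still open, it means among the compounds named here.

Of the compounds shown here, three have been measured so far in a functional assay on HeLa cells for agonist activity at 5-hydroxytryptamine receptor 6 (Homo sapiens), read by cAMP accumulation and immunoassay; a lower number here means a smaller maximal response, a higher number a larger maximal response. Compound 1 `O=S(=O)(c1cccc(F)c1)c1cn(C2CCNC2)c2ncccc12` gives 44%. Compound 2 `CN1CCC(n2cc(S(=O)(=O)c3cccc(F)c3)c3cccnc32)C1` gives 54%. Compound 3 `O=S(=O)(C1=C(Cl)NC2SC=CN12)c1cn(C2CCCNC2)c2ncccc12` gives 47%; its values and those of compound 1 and compound 2 all lie within the usual scatter of one another, so no order among the three can be read from them.

Compound 1 and compound 2 differ in a single place: methyl in place of hydrogen on an amine nitrogen in a ring. This change brought a number 10 percentage points higher from compound 1 to compound 2 (within the scatter).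

The cores of compound 1 and compound 3 are not the same, and the difference between the two cores is not broken down here.

Compound 4 `CN1CCCC(n2cc(S(=O)(=O)C3=C(Cl)NC4SC=CN34)c3cccnc32)C1` has not yet been measured in this assay. It differs from compound 3 in the same kind of change: methyl in place of hydrogen on an amine nitrogen in a ring. Around the place, however, the two cases are not identical: in the step from compound 1 to compound 2 the amine nitrogen sits in a five-membered non-aromatic ring with one nitrogen, the pyrrolidin-3-yl becoming 1-methylpyrrolidin-3-yl, whereas in compound 3 and compound 4 it sits in a six-membered non-aromatic ring with one nitrogen, the piperidin-3-yl becoming 1-methylpiperidin-3-yl.

Within the data shown here, because the one measured example of this change, a number 10 percentage points higher from compound 1 to compound 2 (within the scatter), stayed within the scatter, a step of similar small size is expected here, a number 5 percentage points higher from compound 3 to compound 4 (within the scatter), on a different core and a differently sized ring. For compound 4 the maximal response in this assay is estimated at 52%, with a likely range from 38% to 66%.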

Compound 4, largest response reached (Emax), in percent of the reference or control that the assay uses: 68%
For compound 4 the middle estimate is 16 percentage points below the measured one, outside the stated range (above it).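

In this assay, methyl in place of hydrogen on the ring amine nitrogen, with piperidin-3-yl becoming 1-methylpiperidin-3-yl, gives a number 21 percentage points higher from compound 3 to compound 4 (beyond the scatter). Among these compounds, this step can be read as a real rise in maximal response, whereas the earlier step on the pyrrolidine pair alone cannot, yet the two steps cannot be told apart from each other: the same change on two cores in this assay, a number 10 percentage points higher (within the scatter) from compound 1 to compound 2 and a number 21 percentage points higher (beyond the scatter) from compound 3 to compound 4, 11 percentage points apart, within the scatter of two such steps The data therefore show no sign that the size of the change depends on the core, but they do not show that it is the same on every core, since there are only two pairs and these differ in ring size as well as in core, so neither difference can be weighed on its own.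

The compounds shown leave open how the same change behaves when piperidin-3-yl is placed on the core of compound 1, or pyrrolidin-3-yl on the core of compound 3, pairs that would separate the ring from the core. They also leave open what happens when the amine nitrogen carries ethyl, a longer chain such as propyl, or an acetyl group in place of methyl.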